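Extending compound 1 with a methylpiperazine at the saturated chain

The source may hold more compounds than are shown below. What is called first, only, known or untested is meant among the compounds shown, and "the series" means these compounds.

Compound 1 `Cc1c(C)c2c(c(C)c1N)CC(C)(C)O2` is the starting point. For the measured compounds named here, in a functional assay on the whole organism with Mus musculus as the target (on this read-out higher numbers stand for an effect only at larger amounts of compound and lower numbers for an effect already at smaller amounts), compound 1 gives 7.8 mg/kg, and among the two results in hand this is the only true number. The other result is a limit. Compound 2 `Cc1c(C)c2c(c(N)c1N)CC(C)(C)O2` sits at that limit: in this assay compound 2 gives > 50 mg/kg, which is a boundary of the assay rather than a measured number. Going by the values given here, the step of an at least 6.4-fold higher number from compound 1 to compound 2 (0.80 log units; beyond the scatter) is therefore the only measured step available.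

Compound 3 `Cc1c(C)c2c(c(C)c1N)CC(C)(CN1CCN(C)CC1)O2` is the next compound to be tested. Compared with compound 1, the change is 4-methylpiperazin-1-yl in place of hydrogen on a saturated chain carbon bound to a saturated ring carbon. Among the compounds with values here, the one measured step concerns an amino group replacing a methyl on an aromatic carbon, a different group at a different place, so it says little about adding a 4-methylpiperazin-1-yl group to a saturated chain carbon. Within the data shown here, with no step that bears directly on this change, no movement beyond the scatter is expected in this assay, and compound 3 is estimated at 10 mg/kg, within a range from 4 mg/kg to 30 mg/kg. This estimate means a step of a 1.3-fold higher number from compound 1 to compound 3 (0.11 log units; within the scatter) is expected.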

Compound 3, dose for 50% inhibition: 25.3 mg/kg
For compound 3 the middle estimate is 2.5-fold (0.40 log units) below the measured one, within the range that was stated.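

In this assay, placing 4-methylpiperazin-1-yl on a saturated chain carbon bound to a saturated ring carbon gives a 3.2-fold higher number from compound 1 to compound 3 (0.51 log units; beyond the scatter), so more compound is needed for the same effect. The earlier pair showed a change on an aromatic carbon only, whereas this result shows that the read-out also responds to a change on the saturated chain, and that a large ring-bearing group can be placed there while the effect remains measurable as a true number rather than a limit. Nothing in the data at hand explains why the number rises with this group.

From the compounds shown here alone, with a single group tested at this place, it remains open which part of 4-methylpiperazin-1-yl goes with the step: the ring as a whole, its second nitrogen or its methyl group. A piperazine without the methyl, a morpholine, a simple dimethylamino group or a hydroxyl on the same carbon would each separate these parts, and would show whether the step follows the size of the group or something more particular to this ring.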